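Vero cell cytotoxicity notes on the nitro series

The source may hold more compounds than are shown below. What is called first, only, known or untested is meant among the compounds shown, and "the series" means these compounds.

Measured compounds:
compound 1, `CCCNc1nc(=O)c2cc([N+](=O)[O-])cc([N+](=O)[O-])c2s1`, in an ADME assay on Vero cells (Chlorocebus sabaeus) for cytotoxicity, read by MTT assay, with a stated time of 72 h; on this read-out lower numbers stand for stronger inhibition and higher numbers for weaker inhibition: "not determined" (no result reported)
compound 2, `CC(C)CNc1nc(=O)c2cc([N+](=O)[O-])cc([N+](=O)[O-])c2s1`, in this assay: "not determined" (no result reported)
compound 3, `CCNc1nc(=O)c2cc(C(F)(F)F)cc([N+](=O)[O-])c2s1`, in this assay: > 100000 nM

Compound 1 carries a propylamino group and compound 2 an isobutylamino group on the dinitro core, and for neither does this assay give a number. Compound 3 replaces one nitro group with trifluoromethyl and carries an ethylamino group. For compound 3 the entry is a limit of the assay and not a number, as the limit of > 100000 nM in this assay, at which 1 of the 3 values shown sits, states. Compound 3 therefore stands at the weak end of what this assay can resolve, and it is the only one of the three with any read-out at all.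

Compound 4, `CCCCNc1nc(=O)c2cc(C(F)(F)F)cc([N+](=O)[O-])c2s1`, is still to be measured in this assay. It differs from compound 3 by ethyl in place of hydrogen on a saturated chain carbon, two bonds along the chain from a nitrogen on an aromatic ring. Among the compounds with values here, with only a limit for compound 3 and no step between measured compounds, there is no basis for expecting a step beyond the scatter in either direction.

For compound 4 the estimate is 150000 nM, with a range from 50000 nM to 500000 nM. The expected step that the limit leaves unreadable from compound 3 to compound 4 is thus essentially flat, and most likely the assay again reports only a limit for compound 4.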

Compound 4, half-maximal inhibitory concentration: > 100000 nM
Compound 4 ended at the assay's limit; the forecaster's own chance of this, stated with the estimate: 80%; the middle value is on the limit's open side.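

Compound 3 and compound 4 both end at a limit of this assay and not at a number, so no step can be read between them: the limit of > 100000 nM in this assay, at which 2 of the 4 values shown sit.

The compounds shown leave open whether the ethylamino and butylamino chains differ at all in cytotoxicity, and what number either compound would give in this assay.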